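Trimming the Side Chain: Expected Cytotoxicity of Compound 4

The source may report more compounds than this note shows. Statements on the series, on what has been measured and on what is new or still open speak of the compounds shown alone.

Among the measured compounds shown here, compound 3 `COC(=O)NC[C@H]1CN(c2ccc(-n3cc(-c4ccccn4)cn3)c(F)c2)C(=O)O1` is the one member of this small set with a measured number: in an ADME assay on L02 cells (Homo sapiens) for cytotoxicity, read by MTT assay, with a stated time of 48 h (on this read-out lower numbers stand for stronger inhibition and higher numbers for weaker inhibition), compound 3 gives 71 ug/mL. Compound 1 `O=C(OC[C@H]1CN(c2ccc(-n3cc(-c4ccccn4)cn3)c(F)c2)C(=O)O1)c1ccccc1` reaches only a limit of the assay, giving > 400 ug/mL. Compound 2 `O=CNC[C@H]1CN(c2ccc(-n3cc(-c4ccccn4)cn3)c(F)c2)C(=O)O1` likewise stops at a limit, with > 400 ug/mL. Compound 3 therefore stands alone as a real number, below the limit of > 400 ug/mL in this assay, at which 2 of the 3 values shown sit, at which the other two values sit.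

Compound 4 `CNC(=O)[C@H]1CN(c2ccc(-n3cc(-c4ccccn4)cn3)c(F)c2)C(=O)O1` alters the side chain: methylcarbamoyl in place of ((methoxycarbonyl)amino)methyl on a saturated ring carbon. For the measured compounds named here, no measured step swaps these two groups directly. The steps that touch the same part of the molecule are an at least 5.6-fold lower number from compound 1 to compound 3 (0.75 log units; beyond the scatter) and an at least 5.6-fold lower number from compound 2 to compound 3 (0.75 log units; beyond the scatter), and both show that reshaping this side chain moved the number beyond the scatter. A further reshaping is therefore expected to move the number again, most plausibly upward toward the limit, by a 2.8-fold higher number from compound 3 to compound 4 (0.45 log units; beyond the scatter). Compound 4 is accordingly estimated to give about 200 ug/mL, within a range from 60 ug/mL to 400 ug/mL.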

Compound 4, half-maximal inhibitory concentration: 217 ug/mL
Compound 4: the middle estimate sits 1.1-fold (0.04 log units) below what was measured; measured number inside the range.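

Methylcarbamoyl in place of ((methoxycarbonyl)amino)methyl, on the saturated ring carbon next to the ring oxygen, gives a 3.1-fold higher number from compound 3 to compound 4 (0.49 log units; beyond the scatter) in this assay and is the one step at this position with real numbers at both ends. The comparisons with the other two side chains give an at least 1.8-fold lower number from compound 2 to compound 4 (0.26 log units; that floor lies within the scatter) and an at least 1.8-fold lower number from compound 1 to compound 4 (0.26 log units; that floor lies within the scatter) and neither floor by itself shows a change beyond the scatter. These two steps remain floors because compound 1 and compound 2 each give only a limit: the limit of > 400 ug/mL in this assay, at which 2 of the 4 values shown sit.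

The step from compound 3 to compound 4 replaces the whole side chain at once, and the compounds shown do not separate the effect of its parts. From the compounds shown here alone, how a primary carboxamide, an ethylcarbamoyl, a carboxylic acid or an aminomethyl group on this ring carbon would read in this assay also remains open.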